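Fluoro for chloro on the benzylsulfanyl arm

The source may report more compounds than this note shows. Statements on the series, on what has been measured and on what is new or still open speak of the compounds shown alone.

Compound 1 `CC1=C(C(=O)Nc2ccc(F)cc2)C(c2ccc([N+](=O)[O-])cc2)N=C(SCc2ccc(Cl)cc2)N1` gives 39.7% in a functional assay on the whole organism (artery, strain albino) with Rattus norvegicus as the target, with a stated time of 360 min, at a dose of 10 mg/kg by the oral route; on this read-out higher numbers stand for more inhibition at the one dose given (going by the name of the read-out) and lower numbers for less inhibition. Compound 2 `CC1=C(C(=O)Nc2ccc(F)cc2)C(c2ccc([N+](=O)[O-])cc2)N=C(SCc2ccc(F)cc2)N1` differs from compound 1 by fluoro in place of chloro on an aromatic carbon; in this assay compound 2 gives 33%, and the step is a number 6.7 percentage points lower from compound 1 to compound 2 (within the scatter). Compound 3 `CC1=C(C(=O)Nc2ccc(Br)cc2)C(c2ccc(Cl)cc2Cl)N=C(SCc2ccc(Cl)cc2)N1` gives 39.7% in this assay, level with compound 1 at the digits given. The difference between the cores of compound 1 and compound 3 is not broken down here. Compound 4 `CC1=C(C(=O)Nc2ccc(Br)cc2)C(c2ccc(Cl)cc2Cl)N=C(SCc2ccc(F)cc2)N1` has not been measured; it differs from compound 3 by fluoro in place of chloro on an aromatic carbon, the same change at a place described in the same words as for the earlier pair. Because the matching change gave a number 6.7 percentage points lower from compound 1 to compound 2 (within the scatter), compound 4 is expected to show a number 5.7 percentage points lower from compound 3 to compound 4 (within the scatter) in this assay. The estimate for compound 4 in this assay is 34%, expected to fall between 24% and 44%.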

Compound 4, a percentage reported as inhibition, in the whole organism at one dose (the size of the read-out at that dose, not a potency): 40.7%
Compound 4: middle estimate off by 6.7 percentage points, on the low side; low and high end bracket the measured number.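

On the second core, the same swap of (4-chlorobenzyl)sulfanyl to (4-fluorobenzyl)sulfanyl gives, in this assay, a number 1 percentage points higher from compound 3 to compound 4 (within the scatter). Set beside the earlier step, the two do not differ: the same change on two cores in this assay, a number 6.7 percentage points lower (within the scatter) from compound 1 to compound 2 and a number 1 percentage points higher (within the scatter) from compound 3 to compound 4, 7.7 percentage points apart, within the scatter of two such steps. Both steps lie within the scatter, so this shows that the change carries between these two cores without a detectable difference, but it does not show that the change has a real effect of either sign, or that it would carry to a third core.

Still open, from the compounds shown here alone, is how the series responds when an amine or a carboxylic acid stands in place of the halogen on this arm. Going by these compounds, the separate contributions of the groups that differ between the two cores also remain open.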